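The source may hold more compounds than are shown below. What is called first, only, known or untested is meant among the compounds shown, and "the series" means these compounds.

Compound 2 `CN1C[C@H](C(=O)Nc2ccc(F)c(F)c2)[C@@H](c2ccc(/C=C/C(=O)Nc3ccccc3N)cc2)C1` gives 46 mL/min/kg in an in vitro ADME assay on microsomes from liver (Mus musculus) for pharmacokinetics, read by LC-MS, with a stated time of 10 min, tested at 1 uM (a lower number here means slower removal, a higher number faster removal of the compound), the lowest of the three numbers shown, though within the scatter of both neighbours: compound 1 `CN1C[C@H](C(=O)Nc2ccc(C3CC3)cc2)[C@@H](c2ccc(/C=C/C(=O)Nc3ccccc3N)cc2)C1` gives 60 mL/min/kg and compound 3 `Cc1cc(NC(=O)[C@H]2CN(C)C[C@@H]2c2ccc(/C=C/C(=O)Nc3ccccc3N)cc2)ccc1Cl` gives 65 mL/min/kg. The steps of a 1.3-fold lower number from compound 1 to compound 2 (0.12 log units; within the scatter) and a 1.4-fold higher number from compound 2 to compound 3 (0.15 log units; within the scatter) lie within the scatter, as does a 1.1-fold higher number from compound 1 to compound 3 (0.03 log units; within the scatter). Compound 4 `CN1C[C@H](C(=O)NC2CCCC2)[C@@H](c2ccc(/C=C/C(=O)Nc3ccccc3N)cc2)C1` differs from compound 2 by cyclopentyl in place of 3,4-difluorophenyl on an amide-type nitrogen. All three measured steps exchange one substituted phenyl for another on the same amide-type nitrogen; none replaces the aromatic ring with a non-aromatic one, so they bear on this change only loosely, yet none moved the number beyond the scatter. The step of a 1.1-fold higher number from compound 2 to compound 4 (0.04 log units; within the scatter) is therefore expected to stay within the scatter. Compound 4 is expected at 50 mL/min/kg, within 25 mL/min/kg to 100 mL/min/kg.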

Compound 4, clearance: 61 mL/min/kg
The estimate for compound 4 lay 1.2-fold (0.09 log units) below the measured number; measured number inside the range.
By their numbers in this assay, from the lowest: compounds 2, 1, 4 and 3 (each within the scatter of the next).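

The steps of a 1.3-fold higher number from compound 2 to compound 4 (0.12 log units; within the scatter) and a 1.1-fold lower number from compound 3 to compound 4 (0.03 log units; within the scatter) and a 1.0-fold higher number from compound 1 to compound 4 (0.01 log units; within the scatter) all stay within the scatter in this assay and so extend the earlier picture from phenyl-for-phenyl exchanges to a non-aromatic ring. On this amide-type nitrogen, clearance does not separate cyclopentyl from the three substituted phenyls among these four compounds. No measured evidence bears on why the number holds across this change. The compounds shown leave open whether an amine or a carboxylic acid on the cyclopentyl ring, or a longer chain in its place, would move the number beyond the scatter.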